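A few compounds are considered here, and "the series" means these few. Any claim that something is new, unique, unknown or untested is made for them only; others in the source may bear on it.

Three compounds of one series were tested in a functional assay on HCT-116 cells (Homo sapiens) for inhibition, read by CCK-8 assay, with a stated time of 72 h, tested at 8 uM; on this read-out higher numbers stand for more inhibition of growth at the one concentration tested and lower numbers for less inhibition of growth. Compound 1 `Cc1ccc(SCc2ccc(/C=C/C(=O)Nc3ccccc3N)cc2)cc1` gives 4.93% and is the lowest of the three numbers. Compound 2 `Nc1ccccc1NC(=O)c1ccc(CSc2ccc(C(F)(F)F)cn2)cc1` gives 25.8% in this assay, a number higher than that of compound 1 by more than the scatter, and compound 3 `Nc1ccccc1NC(=O)c1ccc(CSc2ccc(Cl)cc2)cc1` gives 76.6%, the furthest from compound 1 and likewise beyond the scatter. No single-change step between these measured compounds is shown, so none can be read off from them.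

Compound 4 `Nc1ccccc1NC(=O)/C=C/c1ccc(CSCCc2ccccc2)cc1` has not yet been measured. It differs from compound 1 by phenethyl in place of 4-methylphenyl on a sulfur. None of the measured compounds differs from another by this change, so nothing shown tells what it does. The step from compound 1 is therefore expected to be small: a number 5.1 percentage points higher from compound 1 to compound 4 (within the scatter) is estimated to stay within the scatter, in no clear direction. Compound 4 is accordingly expected to give about 10% in this assay, with a range from 0% to 30%.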

Compound 4, percent growth inhibition at one concentration: 10.6%
The estimate for compound 4 lay 0.6 percentage points below the measured number; the range from low to high includes it.
By their numbers in this assay, from the lowest: compounds 1 and 4 (each within the scatter of the next); then compound 2; then compound 3.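

Going by these compounds alone, replacing 4-methylphenyl with phenethyl on the sulfur gives the first single-change step: a number 5.7 percentage points higher from compound 1 to compound 4 (within the scatter) in this assay. At this one concentration, the assay therefore does not separate an aromatic ring carried by 4-methylphenyl from one carried by phenethyl on this sulfur, at least on the core of compound 1. Nothing measured here offers an explanation for this result.

From the compounds shown here alone, whether another group on this sulfur, such as an amine, a carboxylic acid or a longer chain, would produce a step beyond the scatter remains open. It is also unknown whether the same exchange would read alike on the core of compound 3, as this step comes from the core of compound 1 alone.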